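The source may hold more compounds than are shown below. What is called first, only, known or untested is meant among the compounds shown, and "the series" means these compounds.

Compounds measured so far:

Compound 1 `COc1cc(/C=C/C(=O)C(=Cc2ccc(O)cc2)C(=O)/C=C/c2ccc(O)c(OC)c2)ccc1O`: 48700000 nM
Compound 2 `COc1cc(/C=C/C(=O)C(=Cc2ccccc2)C(=O)/C=C/c2ccc(O)c(OC)c2)ccc1O`: 84400000 nM
Compound 3 `CCOc1cc(/C=C/C(=O)C(=Cc2ccc(O)cc2)C(=O)/C=C/c2ccc(O)c(OCC)c2)ccc1O`: 48000000 nM

The three measured compounds share a core that carries a central arylidene group, and they were examined in a functional assay, read by spectrophotometry, with a stated time of 5 min; on this read-out lower numbers stand for stronger inhibition and higher numbers for weaker inhibition. Compound 2 gives 84400000 nM in this assay. Compound 1 differs from compound 2 by one change, (hydroxy in place of hydrogen on an aromatic carbon), and the step is a 1.7-fold lower number from compound 2 to compound 1 (0.24 log units; within the scatter). Compound 3 gives 48000000 nM in this assay; its core differs from that of compound 2 in a way that is not broken down here, and its value and those of compound 1 and compound 2 all lie within the scatter of one another.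

Compound 4 `CCOc1cc(/C=C/C(=O)C(=Cc2ccc(O)c(O)c2)C(=O)/C=C/c2ccc(O)c(OCC)c2)ccc1O` has not yet been measured. It differs from compound 3 by hydroxy in place of hydrogen on an aromatic carbon. For the measured compounds named here, this is the same kind of change as the one from compound 2 to compound 1, but the surroundings differ: in compound 1 the entering hydroxy sits para to a large group, whereas in compound 4 it sits ortho to a hydroxy group and meta to a large group. The earlier change moved the number only within the scatter, so a step of similar size is expected here, a 1.4-fold lower number from compound 3 to compound 4 (0.14 log units; within the scatter), resting on the value of compound 3, 48000000 nM, and on the step of a 1.7-fold lower number from compound 2 to compound 1 (0.24 log units; within the scatter). Compound 4 is therefore estimated to give 35000000 nM in this assay, expected to fall between 15000000 nM and 90000000 nM.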

Compound 4, half-maximal inhibitory concentration: 25200000 nM
Beside the measured number, compound 4's estimate is 1.4-fold (0.14 log units) above it, within the range that was stated.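

In this assay, the change from 4-hydroxyphenyl to 3,4-dihydroxyphenyl gives a 1.9-fold lower number from compound 3 to compound 4 (0.28 log units; within the scatter). Set beside the earlier case of a hydroxy entering in place of hydrogen on an aromatic carbon, the new step does not differ from it, so in these two pairs the change carries from one core to the other with a step of the same size: the same change on two cores in this assay, a 1.7-fold lower number (0.24 log units; within the scatter) from compound 2 to compound 1 and a 1.9-fold lower number (0.28 log units; within the scatter) from compound 3 to compound 4, 1.1-fold (0.04 log units) apart, within the scatter of two such steps. This agreement does not show that the hydroxy has a real effect on inhibition, since each step taken alone lies within the scatter, and two pairs, with the entering hydroxy placed differently on the ring, give no rule for other cores in the series.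

On this ring the compounds shown carry only hydrogen or hydroxy at the changed places, so it stays open what a methoxy, an amine or a fluorine there would do. On the outer rings they carry only methoxy or ethoxy, which leaves open whether a longer chain, such as propoxy or butoxy, would keep the step the same size or produce one beyond the scatter.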